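The source may report more compounds than this note shows. Statements on the series, on what has been measured and on what is new or still open speak of the compounds shown alone.

The compounds here share one core and are compared in a functional assay on A549 cells (Homo sapiens) for cytotoxicity, read by MTT assay; a lower number here means that less compound is needed, a higher number that more compound is needed for the effect. Compound 1 `C=C(C)[C@@H]1C(=O)C=C(C)[C@@H]2CC[C@H](C)C[C@@H]12` gives only a limit in this assay, > 50 ug/mL. Compound 2 `C=C(C)[C@@H]1C(=O)C=C(C)[C@]2(O)CC[C@H](C)C[C@@H]12`, which carries a hydroxyl at a saturated ring carbon, gives 1.86 ug/mL in this assay. Among the compounds with values here, of the two values shown, compound 2 holds the only number. The other value is a limit, (the limit of > 50 ug/mL in this assay, at which 1 of the 2 values shown sits). Compound 3 `C=C(C)[C@@H]1C(=O)C=C(C)[C@@]2(O)CC[C@H](C)C[C@@H]12` is not yet measured. It differs from compound 2 as follows: the two compounds have the same atoms and bonds and differ only in configuration as drawn: 1 of 4 stereo elements differ; a stereocentre at a saturated ring carbon is drawn S in compound 2 and R in compound 3. Within the data shown here, no measured pair differing in the same way is available, so the size of this step is open and a change in either direction, or none beyond the usual scatter, remains possible. For compound 3 the step expected from compound 2 is a 1.9-fold higher number from compound 2 to compound 3 (0.27 log units; within the scatter), a mild weakening. Compound 3 is estimated at 3.5 ug/mL in this assay, within 1 ug/mL to 15 ug/mL.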

Compound 3, concentration for half-maximal effect: > 50 ug/mL
Compound 3: no number, only a limit; the forecaster's own chance of this, stated with the estimate: 15%; middle value at least 14-fold (1.15 log units) away from the limit.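

In this assay, the hydroxyl at this saturated ring carbon counts through how it is drawn in space, and not merely through being present: the change in configuration gives an at least 26-fold higher number from compound 2 to compound 3 (1.42 log units; beyond the scatter). That whole step goes with a single stereocentre, drawn S or R, with nothing else in the structure altered: the fact that compounds 2 and 3 differ only in the configuration as drawn Carrying the hydroxyl is therefore not enough on its own to give a number, as compound 3 has it and still shows only a limit, like compound 1: the limit of > 50 ug/mL in this assay, at which 2 of the 3 values shown sit.

The step from compound 1 to compound 3 cannot be read, as both values are limits. Whether a methoxy group, an amine or a fluorine at this carbon in the S configuration would keep the activity of compound 2 remains open, as does what lies behind the gap between the two configurations.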